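Swapping the Aryl Group on a Cytotoxic Scaffold

The source may report more compounds than this note shows. Statements on the series, on what has been measured and on what is new or still open speak of the compounds shown alone.

In a functional assay on L132 cells (Homo sapiens) for cytotoxicity, read by MTT assay, with a stated time of 72 h (a lower number here means that less compound is needed, a higher number that more compound is needed for the effect), compound 1 `O=C1/C(=C\c2ccc(F)cc2)c2ccccc2N1c1c(Cl)cccc1Cl` gives 13 ug/mL.
In this assay compound 2 `O=C1/C(=C\c2cccc(Br)c2)c2ccccc2N1c1c(Cl)cccc1Cl` gives 19 ug/mL.
In this assay compound 3 `CN(C)c1ccc(/C=C2\C(=O)N(c3c(Cl)cccc3Cl)c3ccccc32)cc1` gives > 100 ug/mL.

For compound 3 this value is only a limit of the assay, (the limit of > 100 ug/mL in this assay, at which 1 of the 3 values shown sits), so no number is known for it.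

Compound 4 `O=C1/C(=C\c2ccccc2[N+](=O)[O-])c2ccccc2N1c1c(Cl)cccc1Cl` differs from compound 3 in one place: 2-nitrophenyl in place of 4-(dimethylamino)phenyl on a double-bonded chain carbon bound to a double-bonded ring carbon. Going by the values given here, two measured steps bear on this change, an at least 7.6-fold higher number from compound 1 to compound 3 (0.88 log units; beyond the scatter) and an at least 5.2-fold higher number from compound 2 to compound 3 (0.72 log units; beyond the scatter); both were at least modest rises on arriving at the 4-(dimethylamino)phenyl group. Removing that group is therefore expected to bring the number back down, although the 2-nitrophenyl group is not the same as the groups in compound 1 or compound 2, so the size of the drop is uncertain. Compound 4 is expected to give 25 ug/mL in this assay, between 8 ug/mL and 100 ug/mL, a step of an at least 4.0-fold lower number from compound 3 to compound 4 (0.60 log units; beyond the scatter).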

Compound 4, concentration for half-maximal effect: 10 ug/mL
Beside the measured number, compound 4's estimate is 2.5-fold (0.40 log units) above it; measured number inside the range.
By their numbers in this assay, from the lowest: compounds 4, 1 and 2 (each within the scatter of the next). At a limit, above all of these: compound 3.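

With 2-nitrophenyl on the double-bonded chain carbon, the number stays within the scatter of the 3-bromophenyl and 4-fluorophenyl compounds, with a 1.9-fold lower number from compound 2 to compound 4 (0.28 log units; within the scatter) and a 1.3-fold lower number from compound 1 to compound 4 (0.11 log units; within the scatter). These three different aryl groups give numbers that cannot be told apart, and among the compounds shown only 4-(dimethylamino)phenyl stands apart, with an at least 10-fold lower number from compound 3 to compound 4 (1.00 log units; beyond the scatter). For compound 3 the value is only a limit: the limit of > 100 ug/mL in this assay, at which 1 of the 4 values shown sits.

Still open, going by these compounds, is how far compound 3 truly lies from the others. On these data alone, it is also open whether a plain amino group or a carboxylic acid on this ring would behave like dimethylamino.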